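Thiophene Replaces Methoxyphenyl on a Shared Core

The source may hold more compounds than are shown below. What is called first, only, known or untested is meant among the compounds shown, and "the series" means these compounds.

Three compounds share one core and differ only in the aryl group attached at one position. Compound 1 `C=C(Br)C(=O)Nc1cccc(-c2cn3nc(-c4ccccc4)sc3n2)c1` gives 1400 nM in a functional assay on HeLa cells (Homo sapiens) for inhibition, read by cell counting, with a stated time of 4 days; a lower number here means a stronger inhibitor, a higher number a weaker inhibitor. Compound 2 `C=C(Br)C(=O)Nc1cccc(-c2cn3nc(-c4ccc(C)cc4)sc3n2)c1` gives 2000 nM, and compound 3 `C=C(Br)C(=O)Nc1cccc(-c2cn3nc(-c4cccc(OC)c4)sc3n2)c1` gives 1100 nM, the smallest of the three numbers. The steps of a 1.4-fold higher number from compound 1 to compound 2 (0.15 log units; within the scatter), a 1.3-fold lower number from compound 1 to compound 3 (0.10 log units; within the scatter) and a 1.8-fold lower number from compound 2 to compound 3 (0.26 log units; within the scatter) all stay within the scatter, so none of the three aryl groups stands apart from the others. Compound 4 `C=C(Br)C(=O)Nc1cccc(-c2cn3nc(-c4cccs4)sc3n2)c1` differs from compound 3 by thiophen-2-yl in place of 3-methoxyphenyl on an aromatic carbon. Among the compounds with values here, no measured step replaces a phenyl-type ring by a thiophene ring, so the only steps that bear on this change are the three aryl swaps at the same place, each within the scatter. Because of a 1.8-fold lower number from compound 2 to compound 3 (0.26 log units; within the scatter) and the two other steps at this position, the change is expected to leave the number roughly where it is. The three steps at this position lead to the expectation that compound 4 shows a step of a 1.2-fold higher number from compound 3 to compound 4 (0.07 log units; within the scatter). Compound 4 is therefore estimated at 1300 nM, with a range from 600 nM to 2800 nM.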

Compound 4, half-maximal inhibitory concentration: 670 nM
Beside the measured number, compound 4's estimate is 1.9-fold (0.29 log units) above it; low and high end bracket the measured number.
By their numbers in this assay, from the lowest: compounds 4, 3, 1 and 2 (each within the scatter of the next, the first and the last beyond it).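

Thiophen-2-yl is the first group at this position to produce steps beyond the scatter: replacing phenyl gives a 2.1-fold lower number from compound 1 to compound 4 (0.32 log units; beyond the scatter), and replacing 4-methylphenyl gives a 3.0-fold lower number from compound 2 to compound 4 (0.47 log units; beyond the scatter), both modest. Against 3-methoxyphenyl, the step is a 1.6-fold lower number from compound 3 to compound 4 (0.22 log units; within the scatter), so compound 4 cannot be separated from compound 3 and cannot be called the strongest of the set. The position therefore accepts a five-membered aromatic ring with one sulfur in place of a six-membered carbon ring, and the number in this assay can shift modestly with that change.

No measurement shown explains these steps. On these data alone, the effect at this position of a furan-2-yl or pyridine ring, or of an amine or a carboxylic acid on the aryl ring, remains open.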